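A few compounds are considered here, and "the series" means these few. Any claim that something is new, unique, unknown or untested is made for them only; others in the source may bear on it.

Working notes on the series. Compound 1 `CCCCCCC#Cc1ccc(S(=O)(=O)Nc2cccc(-c3csc(NC)n3)c2)cc1` gives 36.6% in a functional assay on A-375 cells (Homo sapiens) for antiproliferative activity, read by trypan blue exclusion, with a stated time of 48 h, tested at 1 uM; on this read-out higher numbers stand for a weaker effect at the one concentration tested and lower numbers for a stronger effect. For the measured compounds named here, compound 2 `CCCCCCC#Cc1ccc(S(=O)(=O)Nc2cccc(-c3csc(Nc4ccccc4)n3)c2)cc1` gives 87.1% in this assay, the highest of the two numbers so far; the step of a number 50.5 percentage points higher from compound 1 to compound 2 (beyond the scatter) is the only measured step and it is large. Compound 3 `CCCCCCC#Cc1ccc(S(=O)(=O)Nc2cccc(-c3csc(N)n3)c2)cc1` differs from compound 2 by hydrogen in place of phenyl on a nitrogen on an aromatic ring. Going by the values given here, no measured step covers this exact change, but the step from compound 1 to compound 2 suggests the group on this nitrogen weighs heavily on the read-out, and removing the phenyl is expected to reverse most of it. For compound 3 the expected step is a number 49.1 percentage points lower from compound 2 to compound 3 (beyond the scatter), giving an estimate of 38%, within 12% to 72%.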

Compound 3, a percentage reported as activity, at one concentration (the size of the read-out at that concentration, not a potency): 97.6%
The estimate for compound 3 lay 59.6 percentage points below the measured number, and the stated range ends below it.
By their numbers in this assay, from the lowest: compound 1; then compound 2; then compound 3.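

Hydrogen in place of phenyl on this nitrogen does not move the read-out in this assay back toward the methyl compound, but further from it (a number 10.5 percentage points higher from compound 2 to compound 3 (beyond the scatter)). Hydrogen in place of methyl gives the largest gap in the set (a number 61 percentage points higher from compound 1 to compound 3 (beyond the scatter)), so among these three the number does not follow the heavy-atom count of the group, and only methyl gives a low number. No measurement bears on the reason for this.

From the compounds shown here alone, whether an ethyl or a longer chain on this nitrogen keeps the low number stays open. So does the outcome with an acetyl group there.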